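A few compounds are considered here, and "the series" means these few. Any claim that something is new, unique, unknown or untested is made for them only; others in the source may bear on it.

Three compounds built on one shared core, compound 1 `CCCCc1cnc(CCCc2ccc(-c3ccccc3C(=O)O)cc2)[nH]1`, compound 2 `O=C(O)c1ccccc1-c1ccc(CCc2ncc(C3CCCCC3)[nH]2)cc1` and compound 3 `Cc1ccccc1Cc1cnc(CCc2ccc(-c3ccccc3C(=O)O)cc2)[nH]1`, have been run in an in vitro functional assay on cells for agonist activity at Bombesin receptor subtype-3 (Mus musculus), read by luminescence and calcium flux; a higher number here means that more compound is needed for the effect, a lower number that less compound is needed. Compound 1 gives 382 nM, compound 2 gives 14.7 nM, and compound 3 gives 9.3 nM. Compound 2 therefore stands second highest of the three, with compound 3 nearest and compound 1 furthest away. For the measured compounds named here, the one step that bears on the change at hand is a 1.6-fold lower number from compound 2 to compound 3 (0.20 log units; within the scatter), which replaced the same cyclohexyl by a different aromatic group and stayed within the scatter. Compound 4 `O=C(O)c1ccccc1-c1ccc(CCc2ncc(CCc3ccccc3)[nH]2)cc1` differs from compound 2 in one place: phenethyl in place of cyclohexyl on an aromatic carbon. By analogy, no step beyond the scatter is expected, so the estimated step of a 1.0-fold higher number from compound 2 to compound 4 (0.01 log units; within the scatter) is small, and compound 4 is expected to give 15 nM, between 5 nM and 45 nM in this assay.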

Compound 4, half-maximal effective concentration: 174 nM
For compound 4 the middle estimate is 12-fold (1.06 log units) below the measured one, and the stated range ends below it.
By their numbers in this assay, from the lowest: compounds 3 and 2 (each within the scatter of the next); then compound 4; then compound 1.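

In this assay, the carbon of the five-membered ring that carries these groups does not accept every large group alike: phenethyl in place of cyclohexyl gives a large step (a 12-fold higher number from compound 2 to compound 4 (1.07 log units; beyond the scatter)). The 2-methylbenzyl group had matched cyclohexyl within the scatter, yet phenethyl also falls well short of it (a 19-fold higher number from compound 3 to compound 4 (1.27 log units; beyond the scatter)). Nothing shown accounts for this loss. On these data alone, it remains open whether the loss follows the chain of phenethyl or its aromatic ring, which a cyclohexylethyl group would separate. As far as these compounds go, how a longer chain such as phenylpropyl would behave also stays open.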